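The source may hold more compounds than are shown below. What is called first, only, known or untested is meant among the compounds shown, and "the series" means these compounds.

Compound 1, `Nc1scc(CN2CCN(c3cccnc3)CC2)c1C(=O)c1ccc(Cl)cc1`: 0%
Compound 2, `Nc1scc(CN2CCN(c3c(F)cc(F)cc3F)CC2)c1C(=O)c1ccc(Cl)cc1`: 0%

In an assay on CHO cells for displacement of a labelled ligand from adenosine receptor A1 (Homo sapiens), read by scintillation counting, with a stated time of 120 min, tested at 10 uM (a higher number here means more inhibition at the concentration tested (going by the name of the read-out), a lower number less inhibition), compound 1 gives 0%, and in this assay compound 2 gives 0%. Within the data shown here, compound 2 therefore stands level with compound 1, the only other compound measured; the step of no change at the digits printed from compound 1 to compound 2 (within the scatter) shows that swapping the group on the ring nitrogen left the read-out where it was. Compound 3, `Nc1scc(CN2CCN(c3ccc(F)c(Cl)c3)CC2)c1C(=O)c1ccc(Cl)cc1`, differs from compound 2 in one place: 3-chloro-4-fluorophenyl in place of 2,4,6-trifluorophenyl on an amine nitrogen in a ring. Among the measured compounds shown here, the single measured step bears on this change, as it also exchanged the group on that same ring nitrogen, and it produced nothing beyond the scatter. With no sign in the data that this position moves the read-out, the step of a number 2 percentage points higher from compound 2 to compound 3 (within the scatter) is expected to be none beyond the scatter. Compound 3 is thus estimated at 2% in this assay, in a range from 0% to 15%.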

Compound 3, a percentage reported as inhibition, at one concentration (the size of the read-out at that concentration, not a potency): 0%
For compound 3 the middle estimate is 2 percentage points above the measured one; measured number inside the range.
By their numbers in this assay, from the lowest: compounds 1, 2 and 3 (each within the scatter of the next).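

On the amine nitrogen in the ring, this assay now shows no change at the digits printed from compound 2 to compound 3 (within the scatter), and also no change at the digits printed from compound 1 to compound 3 (within the scatter). A ring carrying chlorine as well as fluorine, 3-chloro-4-fluorophenyl, therefore joins 2,4,6-trifluorophenyl and pyridin-3-yl, and these three six-membered aromatic rings cannot be told apart at this position in this read-out. Nothing in the data offers an explanation for this flat result.

The compounds shown leave open whether any group on this nitrogen can raise the read-out, for example a carboxylic acid on a short chain in place of the aromatic ring. They also leave open whether changing the amine on the shared core would move the read-out when the group on this nitrogen stays the same.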